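Swapping Chloro for Trifluoromethoxy on a Glucagon Antagonist

A few compounds are considered here, and "the series" means these few. Any claim that something is new, unique, unknown or untested is made for them only; others in the source may bear on it.

Measured compounds in a functional assay on CHO cells for antagonist activity at Glucagon receptor (Homo sapiens), read by cAMP accumulation, with stated times of 30 min and 45 min; on this read-out higher numbers stand for weaker inhibition and lower numbers for stronger inhibition:
- compound 1, `C[C@H](c1ccc(C(=O)NCCC(=O)O)cc1)N1C(=O)C(c2cccc(OC(F)(F)F)c2)=N[C@]12CC[C@@H](C(C)(C)C)CC2`, gives 840 nM
- compound 2, `C[C@H](c1ccc(C(=O)NCCC(=O)O)cc1)N1C(=O)C(c2cccc(Cl)c2)=N[C@]12CC[C@@H](C(C)(C)C)CC2`, gives 480 nM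
- compound 3, `CC(C)(C)[C@H]1CC[C@]2(CC1)N=C(c1ccc(Cl)cc1)C(=O)N2Cc1ccc(C(=O)NCCC(=O)O)cc1`, gives 1400 nM

Compound 3 has the highest number of the three. Its gap to compound 1 is within the usual scatter, so the two cannot be told apart, while compound 2 sits beyond the scatter with a clearly lower number.

Compound 4, `CC(C)(C)[C@H]1CC[C@]2(CC1)N=C(c1ccc(OC(F)(F)F)cc1)C(=O)N2Cc1ccc(C(=O)NCCC(=O)O)cc1`, is compound 3 with one change: trifluoromethoxy in place of chloro on an aromatic carbon.

Within the data shown here, only one measured step bears on this. Between compound 1 and compound 2 the same two groups were exchanged in the opposite direction, and there the result was a 1.8-fold lower number from compound 1 to compound 2 (0.24 log units; within the scatter). Read backwards, this hints that putting trifluoromethoxy in place of chloro could raise the number slightly, but that single step stayed within the scatter, and it was seen on a differently substituted core. In this assay the step is therefore expected to be a 1.4-fold higher number from compound 3 to compound 4 (0.15 log units; within the scatter), a small rise at most, not clearly beyond the scatter.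

Compound 4 is estimated at 2000 nM, in the range 800 nM to 5000 nM.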

Compound 4, half-maximal inhibitory concentration: 1900 nM
Compound 4: the middle estimate sits 1.1-fold (0.02 log units) above what was measured; the range from low to high includes it.
By their numbers in this assay, from the lowest: compounds 2, 1, 3 and 4 (each within the scatter of the next, the first and the last beyond it).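

In this assay, the exchange of chloro and trifluoromethoxy can now be read on a second core, where the group sits para to a large group, and the step there is a 1.4-fold higher number from compound 3 to compound 4 (0.13 log units; within the scatter). Until now this exchange rested on a single step, and the two steps can now be set side by side: the same change on two cores in this assay, a 1.8-fold lower number (0.24 log units; within the scatter) from compound 1 to compound 2 and a 1.4-fold lower number (0.13 log units; within the scatter) from compound 4 to compound 3, 1.3-fold (0.11 log units) apart, within the scatter of two such steps On these two cores, then, replacing chloro with the larger trifluoromethoxy group leaves the number within the scatter each time, so this change alone does not clearly separate the compounds.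

The compounds shown leave open whether an amine, a nitrile or a hydroxyl group at this place would move the number beyond the scatter. They also leave open whether the exchange stays this small on any other core.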